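The source may hold more compounds than are shown below. What is called first, only, known or untested is meant among the compounds shown, and "the series" means these compounds.

Three compounds of the series have numbers in a functional assay on A498 cells (Homo sapiens) for inhibition, read by sulforhodamine B assay, with a stated time of 48 h; on this read-out higher numbers stand for weaker inhibition and lower numbers for stronger inhibition. Compound 1 `COc1cc(-c2nn(-c3cccc(NC(=O)Nc4ccc(Cl)c(Cl)c4)c3)cc2-c2ccncc2)ccc1Cl` gives 1140 nM, compound 2 `O=C(Nc1cccc(-n2cc(-c3ccncc3)c(-c3ccc(Cl)c(O)c3)n2)c1)Nc1ccc(Cl)c(Cl)c1` gives 940 nM, and compound 3 `COc1cc(-c2nn(-c3cccc(NC(=O)Nc4cccc(C(F)(F)F)c4)c3)cc2-c2ccncc2)ccc1Cl` gives 960 nM. Compound 2 holds the lowest of the three numbers, yet all three lie within the scatter of one another, so no order among them is claimed. Compound 4 `O=C(Nc1cccc(-n2cc(-c3ccncc3)c(-c3ccc(Cl)c(O)c3)n2)c1)Nc1ccc(Cl)c(C(F)(F)F)c1` differs from compound 2 by trifluoromethyl in place of chloro on an aromatic carbon. The measured step that alters the same amide-side ring, a 1.2-fold lower number from compound 1 to compound 3 (0.07 log units; within the scatter), stayed within the scatter, as did the oxygen step a 1.2-fold lower number from compound 1 to compound 2 (0.08 log units; within the scatter). Among the compounds with values here, no step in this set moved beyond the scatter, so none beyond it is expected here. Compound 4 is estimated at 900 nM, range 450 nM to 1800 nM, an expected step of a 1.0-fold lower number from compound 2 to compound 4 (0.02 log units; within the scatter).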

Compound 4, half-maximal inhibitory concentration: 1400 nM
Estimate against measurement, compound 4: 1.6-fold (0.19 log units) below, within the range that was stated.
By their numbers in this assay, from the lowest: compounds 2, 3, 1 and 4 (each within the scatter of the next).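

In this assay, trifluoromethyl in place of chloro on the aromatic carbon ortho to a chloro group and meta to a large group gives a 1.5-fold higher number from compound 2 to compound 4 (0.17 log units; within the scatter). Unlike the earlier step on this ring, this change keeps the neighbouring chloro group and alters one substituent alone, from 1 heavy atom to 4, without a shift beyond the scatter. No evidence here bears on this result. On these data alone, whether an amine or a carboxylic acid on this carbon would move the number beyond the scatter remains open.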